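The source may report more compounds than this note shows. Statements on the series, on what has been measured and on what is new or still open speak of the compounds shown alone.

Compound 1 `Cc1c(F)c(Oc2cccc(NS(C)(=O)=O)c2)nc(Oc2cccc(C(=N)N)c2)c1F`: 1900 nM
Compound 2 `Cc1c(F)c(Oc2cccc(CC(N)=O)c2)nc(Oc2cccc(C(=N)N)c2)c1F`: > 5000 nM

In an assay on isolated protein for inhibition of serine protease 1 (Bos taurus) (on this read-out higher numbers stand for weaker inhibition and lower numbers for stronger inhibition), compound 1 gives 1900 nM. For compound 2 the read-out is only a limit, > 5000 nM, so compound 2 stands at the upper edge of the numbers shown (the limit of > 5000 nM in this assay, at which 1 of the 2 values shown sits). For the measured compounds named here, the one measured step, an at least 2.6-fold higher number from compound 1 to compound 2 (0.42 log units; beyond the scatter), is the sole guide. Compound 3 `Cc1c(F)c(Oc2cccc(CCC(=O)N(C)C)c2)nc(Oc2cccc(C(=N)N)c2)c1F` carries the change ((dimethylcarbamoyl)methyl in place of carbamoyl on a saturated chain carbon bound to an aromatic carbon). Going by the values given here, since compound 2 itself is known only as a limit, no measured step reaches the region compound 3 enters, and the expected step that the limit leaves unreadable from compound 2 to compound 3 is small. Compound 3 is therefore expected to give about 8000 nM, within 3000 nM to 25000 nM.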

Compound 3, inhibition constant: 4900 nM
Beside the measured number, compound 3's estimate is 1.6-fold (0.21 log units) above it; low and high end bracket the measured number.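

In this assay, swapping the methanesulfonamido group for the amide-bearing chain gives a 2.6-fold higher number from compound 1 to compound 3 (0.41 log units; beyond the scatter), so an amide-bearing chain at this position now has a measured number, and it remains weaker than the methanesulfonamido group. Compound 2 is known only as a limit: the limit of > 5000 nM in this assay, at which 1 of the 3 values shown sits. The change from carbamoylmethyl to 2-(dimethylcarbamoyl)ethyl reads as an at least 1.0-fold lower number from compound 2 to compound 3 (0.00 log units; that floor lies within the scatter), so neither gain nor loss can be claimed for it.

As far as these compounds go, it remains open whether the longer chain or the dimethyl substitution on the amide sets this number, and how a carboxylic acid or an amine on the same chain would read.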